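Swapping Trifluoromethyl for a Diethylaminomethyl Chain

The source may hold more compounds than are shown below. What is called first, only, known or untested is meant among the compounds shown, and "the series" means these compounds.

Of the compounds shown here, two built on one shared core have so far been measured in a functional assay on K562 cells (Homo sapiens) for inhibition, read by MTT assay, with a stated time of 48 h; on this read-out higher numbers stand for weaker inhibition and lower numbers for stronger inhibition. Compound 1 `Cc1ccc(NC(=O)c2cccc(C(F)(F)F)c2)cc1-n1cc(-c2cccnc2)cn1` gives 270 nM, while compound 2 `Cc1ccc(NC(=O)c2ccc(C(F)(F)F)cc2)cc1-n1cc(-c2cccnc2)cn1` gives 760 nM. Among the measured compounds shown here, the single step between them, a 2.8-fold higher number from compound 1 to compound 2 (0.45 log units; beyond the scatter), changes only where the trifluoromethyl sits on the ring attached to the carbonyl carbon. Compound 2 therefore holds the highest of the two numbers, and its nearest neighbour is compound 1, which lies a modest distance lower.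

Compound 3 `CCN(CC)Cc1ccc(C(=O)Nc2ccc(C)c(-n3cc(-c4cccnc4)cn3)c2)cc1` differs from compound 2 in one place: (diethylamino)methyl in place of trifluoromethyl on an aromatic carbon. For the measured compounds named here, no measured step speaks to this change; the one step seen, from compound 1 to compound 2, only moves the trifluoromethyl and never exchanges it for a different group. There is thus no basis for expecting a shift in this assay in either direction, and the best guess is a number close to that of compound 2 with a wide margin. Compound 3 is therefore expected to give about 500 nM, within a range from 120 nM to 2000 nM, which corresponds to an expected step of a 1.5-fold lower number from compound 2 to compound 3 (0.18 log units; within the scatter).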

Compound 3, half-maximal inhibitory concentration: 3260 nM
The estimate for compound 3 lay 6.5-fold (0.81 log units) below the measured number; the whole stated range lies below it.
By their numbers in this assay, from the lowest: compound 1; then compound 2; then compound 3.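

At this place on the ring, para to a large group, the inhibition depends on which group is present as well as on where the trifluoromethyl sits: putting (diethylamino)methyl in place of trifluoromethyl gives a 4.3-fold higher number from compound 2 to compound 3 (0.63 log units; beyond the scatter) in this assay. The earlier step only moved the same group around the ring, whereas this one exchanges it for a different group, with 6 heavy atoms instead of 4, including a nitrogen that counts as a hydrogen-bond acceptor, and here the exchange goes with weaker inhibition. Nothing measured on these compounds says what lies behind this change.

Among the compounds shown here, the single exchange cannot separate the effect of the nitrogen from that of the larger size of the chain, so it remains open how a shorter amine such as (dimethylamino)methyl, a ring amine such as piperazine, or a plain carbon chain without nitrogen would fare at this place. Going by these compounds, it is also open whether (diethylamino)methyl would give a similar step on the ring of compound 1, where the trifluoromethyl sits elsewhere.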